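The compounds below may be only part of what the source reports. "The series", "measured", "known", "first", "only" and "open" are said of these compounds alone.

Of the compounds shown here, three sharing one core have been tested in an assay on isolated protein for inhibition of Rho-associated protein kinase 2 (Homo sapiens), read by radiometric assay; a higher number here means a weaker inhibitor, a lower number a stronger inhibitor. Compound 1 `NCc1ccc(C(=O)Nc2ccncc2F)cc1-c1cccc(C(=O)OCC2CCCO2)c1` gives 2.5 nM, compound 2 `NCc1ccc(C(=O)Nc2ccncc2F)cc1-c1cccc(C(=O)OCC2CCCCO2)c1` gives 12 nM, and compound 3 `CCCOC(=O)c1cccc(-c2cc(C(=O)Nc3ccncc3F)ccc2CN)c1` gives 5.1 nM, so compound 3 stands second highest of the three. The group on the oxygen next to the carbonyl matters: a 2.0-fold higher number from compound 1 to compound 3 (0.31 log units; beyond the scatter), whereas a 2.4-fold lower number from compound 2 to compound 3 (0.37 log units; beyond the scatter), and a 4.8-fold higher number from compound 1 to compound 2 (0.68 log units; beyond the scatter). From the compounds shown here alone, compound 4 `NCc1ccc(C(=O)Nc2ccncc2F)cc1-c1cccc(C(=O)OC2CCCOC2)c1` is still untested; it differs from compound 3 by oxan-3-yl in place of propyl on an oxygen next to a carbonyl group. Because a 2.4-fold lower number from compound 2 to compound 3 (0.37 log units; beyond the scatter) the six-membered ring went with a higher number than the plain chain, a similar modest rise is expected here. The expected step is a 2.0-fold higher number from compound 3 to compound 4 (0.29 log units; within the scatter). In this assay compound 4 is estimated at 10 nM, within a range of 4 nM to 30 nM.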

Compound 4, half-maximal inhibitory concentration: 8.7 nM
The estimate for compound 4 lay 1.1-fold (0.06 log units) above the measured number, and the stated range covers the measured number.
By their numbers in this assay, from the lowest: compound 1; then compounds 3, 4 and 2 (each within the scatter of the next, the first and the last beyond it).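

In this assay, moving from the propyl ester to the oxan-3-yl ester gives a 1.7-fold higher number from compound 3 to compound 4 (0.23 log units; within the scatter) and so adds a ring without a change that can be read, and the (oxan-2-yl)methyl ester shows a 1.4-fold lower number from compound 2 to compound 4 (0.14 log units; within the scatter) as well. The (oxolan-2-yl)methyl ester keeps its edge over this new ring, with a 3.5-fold higher number from compound 1 to compound 4 (0.54 log units; beyond the scatter) here. No measurement shown explains these differences. From the compounds shown here alone, whether oxan-4-yl or oxolan-3-yl would match the (oxolan-2-yl)methyl ester remains open. So does the effect of an amine or a carboxylic acid on the chain.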